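Compound 3 awaits its cytotoxicity result

This account rests on a few compounds, and the source may have more. Where it says the series, first, only, none or still open, it means among the compounds named here.

Measured so far in a functional assay on 1A9 cells (Homo sapiens) for cytotoxicity (a lower number here means that less compound is needed, a higher number that more compound is needed for the effect), on the shared core:
compound 1 `COC1=C(C)C(=O)/C(=C(O)/C=C/c2ccccc2C)C(=O)C1(C)C` gives "not determined" (no result reported)
compound 2 `COC1=C(C)C(=O)/C(=C(O)/C=C/c2c(C)cc(C)cc2C)C(=O)C1(C)C` gives 6.2 ug/mL

Compound 1 has no number to stand on. In this assay compound 1 gives "not determined" (no result reported) as its result, so it cannot be placed against compound 2 or any other compound. The only figure in the series is that of compound 2 at 6.2 ug/mL for the moment.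

The compound now awaiting measurement is compound 3 `COC1=C(C)C(=O)/C(=C(O)/C=C/c2nccs2)C(=O)C1(C)C` and it keeps the core of compound 1. The structural change reads 1,3-thiazol-2-yl in place of 2-methylphenyl on a double-bonded chain carbon bound to a double-bonded chain carbon and, put plainly, 1,3-thiazol-2-yl stands in place of 2-methylphenyl on a double-bonded chain carbon bound to a double-bonded chain carbon.

Among the measured compounds shown here, no measured step exists to guide the size of this change. A moderate step in this assay is expected, a little beyond the usual scatter, towards more compound being needed. That expectation is loose, with compound 2 at 6.2 ug/mL as its only anchor. Compound 3 is expected at 10 ug/mL within a range of 4 ug/mL to 25 ug/mL as the estimate for the coming measurement.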

Compound 3, concentration for half-maximal effect: 3.5 ug/mL
For compound 3 the middle estimate is 2.9-fold (0.46 log units) above the measured one; measured number below the stated range.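

Among the compounds shown here, compound 1 has no number in this assay, so the result for compound 3 of 3.5 ug/mL yields no step between the two. The compounds shown leave open what replacing 2-methylphenyl with 1,3-thiazol-2-yl does to the cytotoxicity result on the shared core. No supporting evidence bears on this result.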